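This account rests on a few compounds, and the source may have more. Where it says the series, first, only, none or still open, it means among the compounds named here.

Within the data shown here, compound 2 `Cc1ccc(NC(=S)NC(=O)c2cn(-c3ccccc3)nc2-c2ccc(C)cc2)cc1` sits with the higher of the two numbers known so far, though in a functional assay on NCI-H460 cells (Homo sapiens) for inhibition, read by CCK-8 assay, with a stated time of 48 h (a higher number here means a weaker inhibitor, a lower number a stronger inhibitor), compound 2 gives 3760 nM, and compound 1 `Cc1ccc(-c2nn(-c3ccccc3)cc2C(=O)NC(=S)Nc2ccc(Cl)cc2)cc1` in this assay gives 3650 nM, a gap that is only a 1.0-fold higher number from compound 1 to compound 2 (0.01 log units; within the scatter). Compound 3 `COc1ccc(-c2nn(-c3ccccc3)cc2C(=O)NC(=S)Nc2ccc(C)cc2)cc1` differs from compound 2 by methoxy in place of methyl on an aromatic carbon. Among the measured compounds shown here, no measured step touches this position; the one known step changed a different ring and stayed within the scatter. A step of about a 1.0-fold higher number from compound 2 to compound 3 (0.00 log units; within the scatter) is therefore expected, meaning no change beyond the scatter. For compound 3 the estimated value is 3800 nM, with a range from 1800 nM to 8000 nM.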

Compound 3, half-maximal inhibitory concentration: 2880 nM
The estimate for compound 3 lay 1.3-fold (0.12 log units) above the measured number; the range from low to high includes it.
By their numbers in this assay, from the lowest: compounds 3, 1 and 2 (each within the scatter of the next).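

In this assay, among these compounds, this is the first measured change at this position: swapping 4-methylphenyl for 4-methoxyphenyl gives a 1.3-fold lower number from compound 2 to compound 3 (0.12 log units; within the scatter), so this spot takes a methoxy group, with its added hydrogen-bond acceptor, without a shift beyond the scatter. No measurement here offers an explanation for this result. Open, from the compounds shown here alone, is whether an amine or a carboxylic acid at this position would move the number beyond the scatter. Also open, going by these compounds, is whether methoxy behaves the same when the other ring carries chloro instead of methyl.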